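Working notes: 2-hydroxyethyl to hydroxymethyl in the series

This account rests on a few compounds, and the source may have more. Where it says the series, first, only, none or still open, it means among the compounds named here.

In a physicochemical assay for lipophilicity, read by HPLC (on this read-out higher numbers stand for higher lipophilicity and lower numbers for lower lipophilicity), compound 1 `Cc1ccsc1C(=CCCN(C)C(CCO)C(=O)NCc1ccc(F)cc1F)c1sccc1C` gives 6.37 and compound 2 `Cc1ccsc1C(=CCCN(C)C(CCO)C(=O)NCc1ccccc1)c1sccc1C` gives 5.71. Compound 2 therefore holds the lower of the two numbers, and the gap lies beyond the scatter. Compound 3 `Cc1ccsc1C(=CCCN(C)C(CO)C(=O)NCc1ccccc1)c1sccc1C` has not yet been measured in this assay. Its structure departs from that of compound 2 in a single place: hydroxy in place of hydroxymethyl on a saturated chain carbon, two bonds along the chain from an amine nitrogen and a carbonyl carbon. This is hydroxy in place of hydroxymethyl on a saturated chain carbon, two bonds along the chain from an amine nitrogen and a carbonyl carbon. The same difference, cut one bond further out, reads 2-hydroxyethyl to hydroxymethyl.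

Among the measured compounds shown here, no measured step covers this place. For the measured compounds named here, the only guide is a number 0.66 log units lower from compound 1 to compound 2 (beyond the scatter), a modest step that exchanges 2,4-difluorophenyl for phenyl elsewhere in the molecule. That step also removes atoms, so a downward step of similar or smaller size is expected, with a wide margin. The expected change is a number 0.31 log units lower from compound 2 to compound 3 (beyond the scatter). The estimate for compound 3 is 5.4, with an expected range from 5 to 5.8.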

Compound 3, partition coefficient: 6.26
Compound 3: the middle estimate sits 0.86 log units below what was measured, and the stated range ends below it.
By their numbers in this assay, from the lowest: compound 2; then compounds 3 and 1 (each within the scatter of the next).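

In this assay, hydroxy in place of hydroxymethyl on a saturated chain carbon, two bonds along the chain from an amine nitrogen and a carbonyl carbon, gives a number 0.55 log units higher from compound 2 to compound 3 (beyond the scatter). The position therefore responds to this small edit, and the number rises although the edit removes a heavy atom and leaves the hydrogen-bond donor and acceptor counts unchanged, whereas the other atom-removing step, a number 0.66 log units lower from compound 1 to compound 2 (beyond the scatter), runs downward, so across these compounds atom loss alone does not set the direction. Nothing at hand bears on the reason for the rise.

Among the compounds shown here, the hydroxy change is seen only with the phenyl group, so it remains open whether the same rise holds with 2,4-difluorophenyl in the molecule. Also open, on these data alone, is how the read-out runs across other groups at this place: a 3-hydroxypropyl chain would extend the comparison with hydroxymethyl and 2-hydroxyethyl, while a methoxymethyl or aminomethyl group would show whether the step depends on the hydroxy group itself.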